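Swapping a pentyl chain for a phenyl in a carbamate

The source may hold more compounds than are shown below. What is called first, only, known or untested is meant among the compounds shown, and "the series" means these compounds.

Measured so far:
- Compound 1 `CC(C)COC(=O)Nc1ccc([Se]C#N)cc1`: in a functional assay on HT-29 cells (Homo sapiens) for cytotoxicity, read by MTT assay, with a stated time of 72 h (on this read-out higher numbers stand for lower toxicity in this test and lower numbers for higher toxicity in this test), compound 1 gives 63700 nM
- Compound 2 `CCCCCCOC(=O)Nc1ccc([Se]C#N)cc1`: in this assay compound 2 gives 69900 nM

Compound 2 stands with compound 1 inside the usual scatter, as the step of a 1.1-fold higher number from compound 1 to compound 2 (0.04 log units; within the scatter) shows; no ordering of the two is warranted. Compound 3 `N#C[Se]c1ccc(NC(=O)OCc2ccccc2)cc1` differs from compound 2 by phenyl in place of pentyl on a saturated chain carbon bound to an oxygen next to a carbonyl group. Within the data shown here, the only measured step bearing on this position is the one from compound 1 to compound 2, and it was within the scatter. A step of similar size is therefore expected, a 1.1-fold lower number from compound 2 to compound 3 (0.03 log units; within the scatter), with no shift beyond the scatter. Compound 3 is estimated at 65000 nM, in a range from 30000 nM to 140000 nM.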

Compound 3, concentration lethal to 50% of the cells: 69100 nM
The estimate for compound 3 lay 1.1-fold (0.03 log units) below the measured number, and the stated range covers the measured number.
By their numbers in this assay, from the lowest: compounds 1, 3 and 2 (each within the scatter of the next).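

With phenyl in place of pentyl on a saturated chain carbon bound to an oxygen next to a carbonyl group, the data show a 1.0-fold lower number from compound 2 to compound 3 (0.00 log units; within the scatter) in this assay, and with phenyl in place of isopropyl they show a 1.1-fold higher number from compound 1 to compound 3 (0.04 log units; within the scatter) at the same place. So this position tolerates an aromatic ring as well as a saturated chain, with no change in the number beyond the scatter. Nothing available explains this insensitivity.

As far as these compounds go, whether an amine or a carboxylic acid at this place, or a much longer chain, would shift the number remains open. From the compounds shown here alone, all three compounds also share one core, so the same swaps on another core remain untested here.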